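The source may hold more compounds than are shown below. What is called first, only, known or untested is meant among the compounds shown, and "the series" means these compounds.

Measured compounds in an ADME assay on MDCK cells (Canis lupus familiaris) for cytotoxicity, read by MTT assay, with a stated time of 48 h; on this read-out lower numbers stand for higher toxicity in this test and higher numbers for lower toxicity in this test:
Compound 1 `CC(C)(C)c1ccc(-c2cn(CC3=C(Cl)c4ccc(-c5cccs5)nc4CC3)nn2)cc1` gives 172 ug/mL.
Compound 2 `COc1ccc(-c2cn(CC3=C(Cl)c4ccc(-c5cccs5)nc4CC3)nn2)cc1` gives only a limit of the assay, > 300 ug/mL.
Compound 3 `Fc1ccc(-c2cn(CC3=C(Cl)c4ccc(-c5cccs5)nc4CC3)nn2)c(F)c1` gives 188 ug/mL.

Compound 2 thus stands at the limit of > 300 ug/mL in this assay, at which 1 of the 3 values shown sits, with no number of its own. Compound 4 `ClC1=C(Cn2cc(-c3ccc(Cl)c(Cl)c3)nn2)CCc2nc(-c3cccs3)ccc21` differs from it by 3,4-dichlorophenyl in place of 4-methoxyphenyl on an aromatic carbon. For the measured compounds named here, the steps that bear on this change are an at least 1.7-fold higher number from compound 1 to compound 2 (0.24 log units; that floor lies within the scatter) and an at least 1.5-fold lower number from compound 2 to compound 3 (0.20 log units; that floor lies within the scatter), both only floors that lie within the scatter, so the change from compound 2 is expected to give no step beyond the scatter in this assay, if anything toward the numbers of compound 1 and compound 3. Compound 4 is therefore estimated at 190 ug/mL, in the range 95 ug/mL to 300 ug/mL, a step of an at least 1.5-fold lower number from compound 2 to compound 4 (0.19 log units; that floor lies within the scatter) that is expected to stay within the scatter.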

Compound 4, half-maximal cytotoxic concentration: > 300 ug/mL
Compound 4: only a limit was reported (the forecaster's own chance of this, stated with the estimate: 30%); middle value at least 1.5-fold (0.19 log units) away from the limit.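

Compound 4 gives only a limit of the assay, > 300 ug/mL, so at this position 3,4-dichlorophenyl reaches that limit without the oxygen of 4-methoxyphenyl. The readable steps are an at least 1.5-fold higher number from compound 3 to compound 4 (0.20 log units; that floor lies within the scatter) and an at least 1.7-fold higher number from compound 1 to compound 4 (0.24 log units; that floor lies within the scatter), while the step between the two limits cannot be read. Compound 4 joins compound 2 at the limit: the limit of > 300 ug/mL in this assay, at which 2 of the 4 values shown sit.

As far as these compounds go, how far either compound lies past that limit stays unknown, so 3,4-dichlorophenyl and 4-methoxyphenyl cannot be ranked. From the compounds shown here alone, whether an amine or a carboxylic acid on the phenyl ring would change the number also stays open.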